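This account rests on a few compounds, and the source may have more. Where it says the series, first, only, none or still open, it means among the compounds named here.

Measured so far in an ADME assay on cells (Macrophage) for cytotoxicity, read by MTT assay, with a stated time of 24 h; a lower number here means that less compound is tolerated, a higher number that more compound is tolerated:

- compound 1 `Cc1ccc(/C=C/C(=O)NNC(=O)c2ccc3c(c2)OCCO3)cc1`: 332000 nM
- compound 2 `O=C(/C=C/c1ccccc1Br)NNC(=O)c1ccc2c(c1)OCCO2`: 315000 nM
- compound 3 `O=C(/C=C/c1cccc(Br)c1)NNC(=O)c1ccc2c(c1)OCCO2`: 351000 nM

Compound 1 sits in a tight group, and none of these three values stands apart from the others. The next compound to be tested is compound 4 `O=C(/C=C/c1cccc([N+](=O)[O-])c1)NNC(=O)c1ccc2c(c1)OCCO2`, which has no value yet. It differs from compound 1 in one place, on a double-bonded chain carbon bound to a double-bonded chain carbon, where 3-nitrophenyl stands in place of 4-methylphenyl: 3-nitrophenyl in place of 4-methylphenyl on a double-bonded chain carbon bound to a double-bonded chain carbon.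

All three measured steps change the group at this same place. They are a 1.1-fold lower number from compound 1 to compound 2 (0.02 log units; within the scatter), a 1.1-fold higher number from compound 1 to compound 3 (0.02 log units; within the scatter) and a 1.1-fold higher number from compound 2 to compound 3 (0.05 log units; within the scatter). Each is within the scatter, so swapping this group has so far left the number in this assay essentially unmoved. The closest guide is a 1.1-fold higher number from compound 1 to compound 3 (0.02 log units; within the scatter), which also replaces the 4-methylphenyl with a 3-substituted phenyl. Within the data shown here, still, no compound with a nitro group has been measured, so the new group is untested here and the range must stay generous.

No step beyond the scatter is expected, in either direction, and the expected change is a 1.0-fold lower number from compound 1 to compound 4 (0.01 log units; within the scatter). For compound 4 the estimated value is 325000 nM, with an expected range from 190000 nM to 500000 nM.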

Compound 4, half-maximal cytotoxic concentration: 323000 nM
Compound 4: the middle estimate sits 1.0-fold (0.00 log units) above what was measured; the range from low to high includes it.
By their numbers in this assay, from the lowest: compounds 2, 4, 1 and 3 (each within the scatter of the next).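

In this assay, among these compounds, the nitro group is the first at this place to bring in nitrogen and oxygen, yet the number stays within the scatter of the earlier compounds, with a 1.0-fold lower number from compound 1 to compound 4 (0.01 log units; within the scatter) and a 1.0-fold higher number from compound 2 to compound 4 (0.01 log units; within the scatter). Among the compounds shown here, the most direct comparison is nitro in place of bromo on an aromatic carbon, which gives a 1.1-fold lower number from compound 3 to compound 4 (0.04 log units; within the scatter), so this position has now accepted a methyl, a bromo and a nitro group with no step beyond the scatter, and no compound here goes against that. The data at hand offer no measurement that could explain this flat result.

Going by these compounds, all four compounds keep a phenyl ring with one small group on it at this place, so it remains open whether an amine or a carboxylic acid on that ring, or a longer chain in its place, would also leave the number unmoved. The compounds shown also share the same core, so they say nothing about whether the number would hold if a different part of the molecule were changed.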